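Chloro to methyl on the fused carbocycle: cytotoxicity notes

A few compounds are considered here, and "the series" means these few. Any claim that something is new, unique, unknown or untested is made for them only; others in the source may bear on it.

In an ADME assay on HEp-2 cells (Homo sapiens) for cytotoxicity, read by CCK-8 assay, with a stated time of 5 days (on this read-out lower numbers stand for higher toxicity in this test and higher numbers for lower toxicity in this test), compound 1 `NCCNc1cc(N2CCc3ccccc3C2)nc2ccccc12` gives 15000 nM. Compound 3 `NCCNc1cc(N2CCCc3ccccc3C2)nc2cc(Cl)ccc12` gives 7500 nM. For compound 2 `NCCNc1cc(N2CCCc3ccccc3C2)nc2ccc(Cl)cc12` this assay reports only a limit, > 3200 nM, and not a number. This is the limit described by the limit of > 3200 nM in this assay, at which 1 of the 3 values shown sits, so compound 2 stands at the edge of what the test can report and cannot be placed against compound 1 or compound 3 beyond lying at or past that limit. Compound 4 `Cc1ccc2nc(N3CCCc4ccccc4C3)cc(NCCN)c2c1` differs from compound 2 by methyl in place of chloro on an aromatic carbon. For the measured compounds named here, no pair of measured compounds differs in one place, so no measured step is available for this change. The numbers of compound 1 and compound 3 sit within the usual scatter of each other. The expectation for compound 4 in this assay is no step beyond the scatter, with the estimated value 10000 nM and a range from 3000 nM to 30000 nM. Relative to the limit that compound 2 shows, the estimated step is a step that the limit leaves unreadable from compound 2 to compound 4.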

Compound 4, half-maximal cytotoxic concentration: 9400 nM
Compound 4: the middle estimate sits 1.1-fold (0.03 log units) above what was measured; measured number inside the range.
By their numbers in this assay, from the lowest: compounds 3, 4 and 1 (each within the scatter of the next).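

In this assay no step can be read from compound 2 to compound 4, because compound 2 stands only at a limit: the limit of > 3200 nM in this assay, at which 1 of the 4 values shown sits.

What methyl in place of chloro on an aromatic carbon does to the read-out stays open, with no pair shown that differs in one place and carries two numbers.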